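A Chlorophenyl Variant Where Two Neighbours Sit at a Limit

The source may report more compounds than this note shows. Statements on the series, on what has been measured and on what is new or still open speak of the compounds shown alone.

Compound 1 `C/N=C(/NC#N)NCCCCn1nc(-c2ccc(C)cc2)ccc1=O` and compound 2 `C/N=C(/NC#N)NCCCCn1nc(Nc2ccccc2)ccc1=O` share one core and differ only in the group on an aromatic carbon. In a functional assay on the whole organism (stomach) with Rattus norvegicus as the target (a lower number here means that less compound is needed, a higher number that more compound is needed for the effect), compound 1 gives > 100 mg/kg, which is a limit of the assay rather than a number. In this assay compound 2 gives > 100 mg/kg, likewise a limit and not a number. The step that the two limits leave unreadable from compound 1 to compound 2 is therefore unreadable, since both values sit at the same point (the limit of > 100 mg/kg in this assay, at which 2 of the 2 values shown sit). Compound 2 thus stands only at a limit in this assay, without a numerical position. Compound 3 `C/N=C(/NC#N)NCCCCn1nc(-c2ccc(Cl)cc2)ccc1=O` has not been measured; it differs from compound 2 by 4-chlorophenyl in place of anilino on an aromatic carbon. For the measured compounds named here, the single recorded step does not bear on this change in a readable way, so no step beyond the scatter can be foreseen for this assay. Compound 3 is expected to give 150 mg/kg, in the range 50 mg/kg to 500 mg/kg. This estimate corresponds to an expected step that the limit leaves unreadable from compound 2 to compound 3, most likely again reported only as a limit.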

Compound 3, dose for half-maximal effect: 100 mg/kg
For compound 3 the middle estimate is 1.5-fold (0.18 log units) above the measured one; low and high end bracket the measured number.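

In this assay, for the compounds shown here, compound 3 gives 100 mg/kg as the first value that is a number rather than a limit of the assay, with a number no higher from compound 2 to compound 3 (the limit leaves the size open) and a number no higher from compound 1 to compound 3 (the limit leaves the size open). Going by these compounds alone, at this aromatic carbon, 4-chlorophenyl is therefore the first group that can be tied to a measured dose. The size of the steps to compound 3 from compound 2 and from compound 1 cannot be read, because those two compounds stand only at a limit: the limit of > 100 mg/kg in this assay, at which 2 of the 3 values shown sit.

The compounds shown leave open how far compound 3 truly lies from compound 1 and compound 2, so nothing yet separates the effect of chloro from that of methyl or anilino. They also leave open whether 4-fluorophenyl, 4-methoxyphenyl or a carboxylic acid at this position, or a longer chain in the shared core, would give a lower dose.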